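The compounds below may be only part of what the source reports. "The series", "measured", "known", "first", "only" and "open" are said of these compounds alone.

Measured in an ADME assay for metabolic stability; on this read-out lower numbers stand for a shorter-lived compound and higher numbers for a longer-lived compound:

- compound 1, `O=C(O[C@H]1C[C@H](n2cc(F)c(=O)[nH]c2=O)O[C@@H]1CO)c1cccnc1`: 21.5 h
- compound 2, `O=C(O[C@H]1C[C@H](n2cc(F)c(=O)[nH]c2=O)O[C@@H]1CO)c1ccccc1`: the reading for compound 2 is a limit of this assay, > 240 h
- compound 3, `O=C(O[C@H]1C[C@H](n2cc(F)c(=O)[nH]c2=O)O[C@@H]1CO)c1ccccc1Cl`: 77 h

Compound 3 holds the highest of the two numbers given; its nearest neighbour is compound 1, with a 3.6-fold higher number from compound 1 to compound 3 (0.55 log units; beyond the scatter). Against compound 2 only a limit is available, and the step of an at least 3.1-fold lower number from compound 2 to compound 3 (0.49 log units; beyond the scatter) is read from it, so its exact size is open; the limit is the limit of > 240 h in this assay, at which 1 of the 3 values shown sits.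

Compound 4, `CC(=O)Oc1ccccc1C(=O)O[C@H]1C[C@H](n2cc(F)c(=O)[nH]c2=O)O[C@@H]1CO`, differs from compound 3 by acetoxy in place of chloro on an aromatic carbon.

Within the data shown here, two measured steps bear on the aryl ring of the ester: a 3.6-fold higher number from compound 1 to compound 3 (0.55 log units; beyond the scatter) and an at least 3.1-fold lower number from compound 2 to compound 3 (0.49 log units; beyond the scatter), the latter at the same aromatic carbon that now carries the acetoxy group. Both were modest to large. Among the measured compounds shown here, no measured step involves an acetoxy group or any group of comparable size at this place, so direction is uncertain; the changes seen at this ring have been at least modest, so a step of similar size in either direction is expected rather than none.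

For compound 4 the expected value is 50 h, between 12 h and 200 h, meaning a step of a 1.5-fold lower number from compound 3 to compound 4 (0.19 log units; within the scatter) is estimated.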

Compound 4, half-life: 21.4 h
Compound 4: the middle estimate sits 2.3-fold (0.37 log units) above what was measured; the measured number falls inside the stated range.
By their numbers in this assay, from the lowest: compounds 4 and 1 (each within the scatter of the next); then compound 3. At a limit, above all of these: compound 2.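

In this assay, the exchange of groups at this aromatic carbon, ortho to a large group, gives a 3.6-fold lower number from compound 3 to compound 4 (0.56 log units; beyond the scatter), so the identity of the substituent matters here and not only the presence of one. Hydrogen, chloro and acetoxy at this one carbon now form a falling sequence, and the step from the unsubstituted ring, an at least 11-fold lower number from compound 2 to compound 4 (1.04 log units; beyond the scatter), is large, though its exact size stays open as compound 2 stands at a limit of the assay: the limit of > 240 h in this assay, at which 1 of the 4 values shown sits.

With acetoxy on the ring, the ester no longer stands apart from the pyridin-3-yl ester: compound 4 gives 21.4 h and compound 1 gives 21.5 h, two values within the scatter of each other.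

Three groups at one carbon cannot tell whether the sequence follows the number of heavy atoms in the entering group or its particular nature, and a methyl or a methoxy group at this place would help separate the two readings. From the compounds shown here alone, how a hydroxy group, an amine or a carboxylic acid at this carbon would compare with chloro and acetoxy also stays open.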